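Chloro for Methyl on a Fused Ring: An Expected Gain

This account rests on a few compounds, and the source may have more. Where it says the series, first, only, none or still open, it means among the compounds named here.

Compound 1 `Cc1ccc2nc(Nc3nc(Nc4ccc(S(N)(=O)=O)cc4)ncc3F)sc2c1` gives 6390 nM
Compound 2 `NS(=O)(=O)c1ccc(Nc2ncc(F)c(Nc3nc4ccc(Cl)cc4s3)n2)cc1` gives 2790 nM
Compound 3 `Cc1ccc2nc(Nc3ccnc(Nc4ccc(S(C)(=O)=O)cc4)n3)sc2c1` gives 4440 nM

All three compounds were tested in a functional assay on MDA-MB-231 cells (Homo sapiens) for antiproliferative activity, read by MTT assay, with a stated time of 48 h; a higher number here means a weaker inhibitor, a lower number a stronger inhibitor. Compound 1 and compound 2 share a core and differ in one place, (chloro in place of methyl on an aromatic carbon). That single swap gave a 2.3-fold lower number from compound 1 to compound 2 (0.36 log units; beyond the scatter).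

Compound 3 stands on a different core, and the difference between its core and that of compound 1 is not broken down here. In this assay compound 3 gives a number that sits near compound 1 and somewhat apart from compound 2, but these gaps fall within the usual scatter, so no order among them can be read.

Compound 4 `CS(=O)(=O)c1ccc(Nc2nccc(Nc3nc4ccc(Cl)cc4s3)n2)cc1` has not yet been measured. It arises from compound 3 by chloro in place of methyl on an aromatic carbon. The place description matches that of the change from compound 1 to compound 2 word for word, so this is the same change made on a second core.

Because the change gave a 2.3-fold lower number from compound 1 to compound 2 (0.36 log units; beyond the scatter), a step of similar size is expected here, and the estimate for a 2.2-fold lower number from compound 3 to compound 4 (0.35 log units; beyond the scatter) rests on that one precedent alone. Among the measured compounds shown here, since only a single earlier example of the swap exists, and on a different core, the expectation is held loosely. Compound 4 is estimated at 2000 nM in this assay, with a plausible range from 1000 nM to 4500 nM.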

Compound 4, half-maximal inhibitory concentration: > 50000 nM
Compound 4: no number, only a limit (the forecaster's own chance of this, stated with the estimate: 2%); at least 25-fold (1.39 log units) between middle value and limit.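

Compound 4 has no number in this assay, only a limit: the limit of > 50000 nM in this assay, at which 1 of the 4 values shown sits. Chloro in place of methyl on an aromatic carbon gave a 2.3-fold lower number from compound 1 to compound 2 (0.36 log units; beyond the scatter), yet the same swap on the second core gave an at least 11-fold higher number from compound 3 to compound 4 (1.05 log units; beyond the scatter), so the effect of this change did not carry from one core to the other, and its direction reversed: the same change on two cores in this assay, a 2.3-fold lower number (0.36 log units; beyond the scatter) from compound 1 to compound 2 and an at least 11-fold higher number (1.05 log units; beyond the scatter) from compound 3 to compound 4, at least 25-fold (1.41 log units) apart, beyond the scatter of two such steps This shows that, in this series, a step measured on one core was a poor guide to the same step on the other, but with only two pairs it does not show which feature of the cores decides the outcome, or whether either step is typical of its core.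

The compounds shown leave open what the same swap would do on a core that keeps only part of the difference, for example one that pairs the sulfonamide of compound 1 with the unfluorinated ring of compound 3. They also leave open how other groups in the same place, such as a methoxy group or an amine, would behave on each core, and whether either would follow methyl or chloro.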